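Chain lengthening beside the fluoro in a cell-growth assay

The source may report more compounds than this note shows. Statements on the series, on what has been measured and on what is new or still open speak of the compounds shown alone.

Measured compounds:
compound 1 `CN(C)C(=O)c1cc2cnc(Nc3ccc(C(=O)NCCCCCN=C=S)cc3)nc2n1C1CCCC1` gives 50.3%
compound 2 `CN(C)C(=O)c1cc2cnc(Nc3ccc(C(=O)NCCCCCCN=C=S)cc3)nc2n1C1CCCC1` gives 49.4%
compound 3 `CN(C)C(=O)c1cc2cnc(Nc3ccc(C(=O)NCCCCCN=C=S)cc3F)nc2n1C1CCCC1` gives 36.1%

All three were tested in a functional assay on NCI-H1299 cells (Homo sapiens) for inhibition, read by CCK-8 assay, with a stated time of 72 h, tested at 1 uM; on this read-out lower numbers stand for a weaker effect and higher numbers for a stronger effect at the one concentration tested. Compound 4 `CN(C)C(=O)c1cc2cnc(Nc3ccc(C(=O)NCCCCCCN=C=S)cc3F)nc2n1C1CCCC1` has not yet been measured there. Compound 4 differs from compound 3 by a group of 4 heavy atoms (2 carbon, 1 nitrogen, 1 sulfur; no ring) in place of a group of 3 heavy atoms (1 carbon, 1 nitrogen, 1 sulfur; no ring), on a saturated chain carbon, five bonds along the chain from an amide-type nitrogen. This is the same change that turns compound 1 into compound 2, where it gave a number 0.9 percentage points lower from compound 1 to compound 2 (within the scatter). The cores of these two pairs differ by fluoro in place of hydrogen on an aromatic carbon, a change that on its own gave a number 14.2 percentage points lower from compound 1 to compound 3 (beyond the scatter).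

For compound 4 a step of about a number 1.1 percentage points lower from compound 3 to compound 4 (within the scatter) is expected because a number 0.9 percentage points lower from compound 1 to compound 2 (within the scatter) shows the chain change doing little in the first pair. Compound 4 is therefore estimated at 35%, expected to fall between 24% and 46%.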

Compound 4, a percentage reported as inhibition, at one concentration (the size of the read-out at that concentration, not a potency): 29.1%
Beside the measured number, compound 4's estimate is 5.9 percentage points above it; the measured number falls inside the stated range.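

In this assay the longer chain on the fluoro core gave a number 7 percentage points lower from compound 3 to compound 4 (within the scatter) and so behaved as it did on the core without fluoro: the same change on two cores in this assay, a number 0.9 percentage points lower (within the scatter) from compound 1 to compound 2 and a number 7 percentage points lower (within the scatter) from compound 3 to compound 4, 6.1 percentage points apart, within the scatter of two such steps. Seen from the other side, fluoro in place of hydrogen on the longer-chain compounds gave a number 20.3 percentage points lower from compound 2 to compound 4 (beyond the scatter) and matched its earlier step: the same change on two cores in this assay, a number 14.2 percentage points lower (beyond the scatter) from compound 1 to compound 3 and a number 20.3 percentage points lower (beyond the scatter) from compound 2 to compound 4, 6.1 percentage points apart, within the scatter of two such steps. Each change therefore carried over between these two cores with no difference beyond the scatter, but these four compounds, tested at a single concentration, do not show that this holds on other cores or give a potency for any of them.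

Going by these compounds, whether a still longer chain would follow the same pattern remains open. So does the effect of chloro in place of the fluoro.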